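The source may hold more compounds than are shown below. What is called first, only, known or untested is meant among the compounds shown, and "the series" means these compounds.

Measured compounds:
compound 1, `COc1ccc(C(=O)NC(=S)Nc2cccc(-c3nc4ccccc4[nH]3)c2)cc1OC`: > 10000 nM in a functional assay on MDA-MB-231 cells (Homo sapiens) for cytotoxicity, read by WST assay, with a stated time of 48 h; a lower number here means a stronger inhibitor, a higher number a weaker inhibitor
compound 2, `COc1ccc(C(=O)NC(=O)Nc2cccc(-c3nc4ccccc4[nH]3)c2)cc1OC`: "not determined" (no result reported) in this assay
compound 3, `CCOc1ccc(C(=O)NC(=S)Nc2cccc(-c3nc4ccccc4[nH]3)c2)cc1OCC`: "not determined" (no result reported) in this assay

Compound 1 gives > 10000 nM in this assay, which is a limit of the assay and not a number. It therefore sits at the limit of > 10000 nM in this assay, at which 1 of the 3 values shown sits; no single number is available for any compound of the series, and compound 2 and compound 3 bring no result at all.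

Compound 4, `O=C(NC(=S)Nc1cccc(-c2nc3ccccc3[nH]2)c1)c1ccccc1`, is the next to be measured in this assay. It differs from compound 1 by phenyl in place of 3,4-dimethoxyphenyl on a carbonyl carbon.

Among the measured compounds shown here, with only a limit for compound 1 in this assay, no measured step sets a scale. The expected step that the limit leaves unreadable from compound 1 to compound 4 is none beyond the scatter, in either direction. Compound 4 is estimated at 20000 nM, with a range from 8000 nM to 60000 nM.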

Compound 4, half-maximal inhibitory concentration: > 10000 nM
Compound 4: only a limit was reported; the forecaster's own chance of this, stated with the estimate: 75%; the middle value does not contradict the limit.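

No step can be read from compound 1 to compound 4, since both stand only at a limit of this assay: the limit of > 10000 nM in this assay, at which 2 of the 4 values shown sit.

On these data alone, whether phenyl in place of 3,4-dimethoxyphenyl on a carbonyl carbon changes potency at all remains open, as does the actual potency of either compound.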